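The source may hold more compounds than are shown below. What is called first, only, known or untested is meant among the compounds shown, and "the series" means these compounds.

Measured compounds:

Compound 1 `CN(Cc1cc(C(F)(F)F)cc(C(F)(F)F)c1)C(=O)c1c(OCCCC(F)(F)F)c2ccccc2n(C)c1=O` gives 240 nM
Compound 2 `CN(Cc1cc(C(F)(F)F)cc(C(F)(F)F)c1)C(=O)c1c(OCCCC2CCN(C(=O)OC(C)(C)C)CC2)c2ccccc2n(C)c1=O` gives 7.7 nM
Compound 3 `CN(Cc1cc(C(F)(F)F)cc(C(F)(F)F)c1)C(=O)c1c(OCCCC2CCN(C(=O)OC3(C)CC3)CC2)c2cccnc2n(C)c1=O` gives 3 nM

All three were tested in an assay for inhibition of phosphatidylcholine:ceramide cholinephosphotransferase 2 (Mus musculus), read by mass spectrometry, with stated times of 60 min and 30 min; on this read-out lower numbers stand for stronger inhibition and higher numbers for weaker inhibition. Compound 1 stands at the highest number of the three, that is, it is the weakest inhibitor of the set, and both gaps separating it from compound 2 and from compound 3 are beyond the usual scatter of repeated measurements. The shared core and the amide part are the same in all three; what varies is the group carried on the chain that hangs from the ring oxygen.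

Compound 4 `CN(Cc1cc(C(F)(F)F)cc(C(F)(F)F)c1)C(=O)c1c(OCCCC2CCCCC2)c2ccccc2n(C)c1=O` has not yet been measured in this assay. It differs from compound 1 in one place:

cyclohexyl in place of trifluoromethyl on a saturated chain carbon, three bonds along the chain from an oxygen on an aromatic ring

Within the data shown here, since no single-change pair is measured here, the direction of this step must be judged from the whole set. A lower number, and so stronger inhibition, is expected for compound 4, because compound 2, which also carries a six-membered saturated ring on the same chain, gives 7.7 nM. The expected step of an 8.0-fold lower number from compound 1 to compound 4 (0.90 log units; beyond the scatter) lies beyond the scatter. Compound 4 is therefore estimated at 30 nM, within the range 8 nM to 110 nM.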

Compound 4, half-maximal inhibitory concentration: 190 nM
Estimate against measurement, compound 4: 6.3-fold (0.80 log units) below; measured number above the stated range.
By their numbers in this assay, from the lowest: compound 3; then compound 2; then compounds 4 and 1 (each within the scatter of the next).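

In this assay the change from trifluoromethyl to cyclohexyl at the end of the chain gives a 1.3-fold lower number from compound 1 to compound 4 (0.10 log units; within the scatter) and so cannot be told apart from no change at all. A six-membered ring of carbon only is thus not enough on this chain to reach the much lower number of compound 2 at 7.7 nM in the same assay, since compound 4 stands at 190 nM and differs from it in the make-up of that ring and the group the ring carries. Nothing available explains why this swap leaves the number where it is.

As far as these compounds go, it remains open which part of the ring group in compound 2 goes with its lower number: a free piperidine amine or an amide in place of the carbamate would separate the ring nitrogen from what sits on it. From the compounds shown here alone, how a shorter or longer chain ending in cyclohexyl would behave also remains open.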